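Swapping a phenyl for a chloro on compound 2

The source may hold more compounds than are shown below. What is called first, only, known or untested is meant among the compounds shown, and "the series" means these compounds.

Of the compounds shown here, two have so far been tested in a functional assay on K562 cells (Homo sapiens) for antiproliferative activity, read by MTT assay, with a stated time of 24 h; on this read-out lower numbers stand for stronger inhibition and higher numbers for weaker inhibition. For the measured compounds named here, compound 1, `COc1cc(OC)c(OC)cc1/C=C/C(=O)c1ccc(OC)c2c1OC(C)(C)C=C2`, is the first of them. Compound 2, `COc1ccc(C(=O)/C=C/c2ccc(-c3ccccc3)cc2)c2c1C=CC(C)(C)O2`, shares the same core and differs in the aryl part of its chain. In this assay compound 1 gives only a limit, > 10000 nM. In this assay compound 2 likewise gives only a limit, > 10000 nM. Going by the values given here, both values sit at the limit of > 10000 nM in this assay, at which 2 of the 2 values shown sit, so neither compound has a number that could be set against the other, and compound 2 stands at the limit with no measured compound placed below it.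

Compound 3, `COc1ccc(C(=O)/C=C/c2ccc(Cl)cc2)c2c1C=CC(C)(C)O2`, has not yet been measured in this assay. It differs from compound 2 by chloro in place of phenyl on an aromatic carbon. Among the compounds with values here, no step between measured compounds exists here, since both measured values are limits. The step is expected to be small, a step that the limit leaves unreadable from compound 2 to compound 3, in either direction or none beyond the scatter. Compound 3 is accordingly expected to give about 12000 nM, within 3000 nM to 50000 nM, with a fair chance that this assay again reports only a limit.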

Compound 3, half-maximal inhibitory concentration: > 10000 nM
Compound 3 ended at the assay's limit (the forecaster's own chance of this, stated with the estimate: 60%); the middle value does not contradict the limit.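

No step can be read between compound 2 and compound 3 in this assay since each gives only a limit and not a number: the limit of > 10000 nM in this assay, at which 3 of the 3 values shown sit.

The compounds shown leave open whether chloro and phenyl differ at all in this setting, and which change to the shared core or chain would yield a measurable value.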